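Ring-size swap at the aromatic nitrogen of compound 1

The compounds below may be only part of what the source reports. "The series", "measured", "known", "first", "only" and "open" are said of these compounds alone.

Of the compounds shown here, three carry numbers so far: compound 1 `O=c1c(S(=O)(=O)c2ccc(F)cc2F)cc2cnc(Nc3ccc4[nH]ccc4c3)nc2n1CC1CC1`, compound 2 `Cn1c(=O)c(S(=O)(=O)c2ccc(F)cc2N)cc2cnc(Nc3ccc4[nH]ccc4c3)nc21` and compound 3 `Cn1c(=O)c(S(=O)(=O)c2ccc(F)cc2F)cc2cnc(Nc3ccncn3)nc21`. In a functional assay on DU-145 cells (Homo sapiens) for inhibition, read by trypan blue exclusion, with a stated time of 72 h (on this read-out lower numbers stand for stronger inhibition and higher numbers for weaker inhibition), compound 1 gives 1000 nM, compound 2 gives 3000 nM and compound 3 gives 50000 nM. Compound 1 thus has the lowest number of the three, and both gaps to it lie beyond the usual scatter. The next compound, compound 4 `O=c1c(S(=O)(=O)c2ccc(F)cc2F)cc2cnc(Nc3ccc4[nH]ccc4c3)nc2n1C1CCCC1`, keeps the core of compound 1 and differs only in the group on an aromatic nitrogen: cyclopentyl in place of cyclopropylmethyl on an aromatic nitrogen. Within the data shown here, each side carries one non-aromatic ring of carbon only, and no measured pair isolates this change. The step of no change at the digits printed from compound 1 to compound 4 (within the scatter) is expected to be none beyond the scatter. Compound 4 is estimated at 1000 nM, in a range from 400 nM to 2500 nM.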

Compound 4, half-maximal inhibitory concentration: 5000 nM
Estimate against measurement, compound 4: 5.0-fold (0.70 log units) below; the whole stated range lies below it.
By their numbers in this assay, from the lowest: compound 1; then compounds 2 and 4 (each within the scatter of the next); then compound 3.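

In this assay the group on the aromatic nitrogen matters: cyclopentyl in place of cyclopropylmethyl, with the rest of the structure unchanged, gives a 5.0-fold higher number from compound 1 to compound 4 (0.70 log units; beyond the scatter). This single step at the position shows that two groups, each carrying one non-aromatic ring of carbon only, are not interchangeable there. Nothing at hand explains the step. Still open, on these data alone, is how an open chain such as isopropyl, or a cyclopentyl ring bearing an amine, would read on this nitrogen. As far as these compounds go, whether the step carries over to other groups on the sulfonyl-linked phenyl ring also remains open.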